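The source may report more compounds than this note shows. Statements on the series, on what has been measured and on what is new or still open speak of the compounds shown alone.

Compound 1, `CCCCn1c(-c2ccc(OC)cc2)cnc1NC(=O)c1ccc(F)cc1`: > 100000 nM
Compound 2, `COc1ccc(-c2cnc(NC(=O)C3CCCC3)n2C)cc1`: > 100000 nM

Both results in a toxicity assay on THP-1 cells (Homo sapiens) for inhibition (a lower number here means that less compound is tolerated, a higher number that more compound is tolerated), are limits rather than numbers. For compound 1 the value > 100000 nM is a limit of the assay. For compound 2 the value > 100000 nM is likewise a limit. Compound 2 thus stands at the limit of > 100000 nM in this assay, at which 2 of the 2 values shown sit, and nothing separates it from compound 1. Compound 3, `COc1ccc(-c2cnc(NC(=O)c3ccc(Br)cc3)n2C)cc1`, is not yet measured; it differs from compound 2 by 4-bromophenyl in place of cyclopentyl on a carbonyl carbon. Among the compounds with values here, no measured step between compounds exists here. Since compound 1 also carries an aromatic amide and sits at the limit, compound 3 is expected to show a step of a number no higher from compound 2 to compound 3 (the limit leaves the size open), none beyond the scatter. The expected value for compound 3 in this assay is 100000 nM, between 30000 nM and 300000 nM.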

Compound 3, half-maximal cytotoxic concentration: > 100000 nM
Compound 3: a limit, no number; the forecaster's own chance of this, stated with the estimate: 70%; the middle value sits exactly at the limit.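

Compound 2 and compound 3 both give only a limit in this assay, so no step can be read between them: the limit of > 100000 nM in this assay, at which 3 of the 3 values shown sit.

The compounds shown leave open whether 4-bromophenyl in place of cyclopentyl on a carbonyl carbon changes how much compound is tolerated.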